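Chain shortening in the amino-diol series

This account rests on a few compounds, and the source may have more. Where it says the series, first, only, none or still open, it means among the compounds named here.

Two amino-diols with long saturated chains have been run in a functional assay on WiDr cells (Homo sapiens) for inhibition; a lower number here means a stronger inhibitor, a higher number a weaker inhibitor. Compound 1 `CCCCCCCCCCCCCC[C@@H](N)[C@@H](O)CO` gives 2990 nM in this assay. Compound 2 `CCCCCCCCCCCCCCCCCC[C@H](N)[C@H](O)CO` gives 3470 nM in this assay, the highest of the two numbers; its nearest neighbour is compound 1, and the gap between them lies within the scatter, so the two stand level.

The next compound, compound 3 `CCCCCCCCCCCCCC[C@H](N)[C@H](O)CO`, keeps the head group and configuration of compound 2 and shortens the chain: hydrogen in place of butyl on a saturated chain carbon, ten or more bonds along the chain from an amine nitrogen. Going by the values given here, no measured pair in this set differs in one place only, so nothing here isolates the effect of chain length by itself. What is known is that compound 1 and compound 2, which differ in chain length among other things, sit within the scatter of each other, which gives no sign that chain length moves the number much in this assay.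

On that basis compound 3 is expected to stay close to compound 2, with a 1.1-fold lower number from compound 2 to compound 3 (0.02 log units; within the scatter) as the expected step, not beyond the scatter in either direction. The estimate for compound 3 in this assay is 3300 nM, with a range from 1500 nM to 7500 nM.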

Compound 3, half-maximal inhibitory concentration: 2760 nM
For compound 3 the middle estimate is 1.2-fold (0.08 log units) above the measured one, and the stated range covers the measured number.
By their numbers in this assay, from the lowest: compounds 3, 1 and 2 (each within the scatter of the next).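

The change of butyl to hydrogen on a saturated chain carbon now stands as a single change, and in this assay it reads as a 1.3-fold lower number from compound 2 to compound 3 (0.10 log units; within the scatter). At this position the chain can therefore lose butyl with no shift beyond the scatter, which the earlier pair could only hint at, since it differed in more than one place. Configuration gives a level reading too, with a 1.1-fold lower number from compound 1 to compound 3 (0.03 log units; within the scatter), and that comparison speaks to stereochemistry alone because of one structural fact: the fact that compounds 1 and 3 differ only in the configuration as drawn

As far as these compounds go, whether the number stays level with a chain much shorter than that of compound 3, or a longer chain than that of compound 2, remains open. From the compounds shown here alone, the response to an amide or a carboxylic acid in place of the amine is equally open, as is the effect of inverting only one of the two stereocentres.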